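The source may hold more compounds than are shown below. What is called first, only, known or untested is meant among the compounds shown, and "the series" means these compounds.

Compound 1 (`CCOc1ccc2c(c1)NC(=O)Nc1cnc(C#N)c(n1)OCCCCCO2`) was examined in a functional assay on NCI-H1299 cells (Homo sapiens), read by flow cytometry; on this read-out lower numbers stand for an effect already at smaller amounts and higher numbers for an effect only at larger amounts of compound. In this test compound 1 gives > 10000 nM, which is a limit of the assay and not a number. Compound 2 (`N#Cc1ncc2nc1OCC/C=C\COc1ccc(OCCO)cc1NC(=O)N2`) gives > 10000 nM, which is likewise a limit. Going by the values given here, compound 1 therefore has no numerical position and stands level with the only other measured compound.

Compound 3 (`N#Cc1ncc2nc1OCCCCCOc1ccc(OCCO)cc1NC(=O)N2`) departs from compound 1 in one place: hydroxy in place of hydrogen on a saturated chain carbon, two bonds along the chain from an oxygen on an aromatic ring. This places hydroxy in place of hydrogen on a saturated chain carbon, two bonds along the chain from an oxygen on an aromatic ring, turning ethoxy into 2-hydroxyethoxy. Among the compounds with values here, no measured pair shows the size of this change in this assay. Given (the limit of > 10000 nM in this assay, at which 2 of the 2 values shown sit), the expected step that the limit leaves unreadable from compound 1 to compound 3 stays within the scatter, with no clear direction. Compound 3 is estimated at 12000 nM, with an expected range from 3000 nM to 30000 nM.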

Compound 3, half-maximal effective concentration: > 10000 nM
Compound 3 gave a limit, no number; the forecaster's own chance of this, stated with the estimate: 70%; the middle value is on the limit's open side.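

In this assay no step can be read between compound 1 and compound 3, since both results are limits and not numbers: the limit of > 10000 nM in this assay, at which 3 of the 3 values shown sit.

The compounds shown leave open how large the change from ethoxy to 2-hydroxyethoxy is, and whether any of them reaches a numerical value.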